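The compounds below may be only part of what the source reports. "The series", "measured", "known", "first", "only" and "open" are said of these compounds alone.

Of the compounds shown here, three on a shared core have so far been measured in a functional assay on HT-29 cells (Homo sapiens) for cytotoxicity, read by MTT assay, with a stated time of 72 h; on this read-out lower numbers stand for stronger inhibition and higher numbers for weaker inhibition. Compound 1 `COc1cccc(N2C(=O)CS/C2=N\c2csc(-c3ccccc3)c2)c1` gives 38300 nM. Compound 2 `COc1cccc(N2C(=O)CS/C2=N\c2csc(-c3ccc(C)cc3)c2)c1` reaches only the assay limit of > 50000 nM (the limit of > 50000 nM in this assay, at which 1 of the 3 values shown sits). Compound 3 `COc1ccc(-c2cc(/N=C3\SCC(=O)N3c3cccc(OC)c3)cs2)cc1` gives 11700 nM, the lowest of the two numbers recorded; its nearest neighbour is set apart by a 3.3-fold lower number from compound 1 to compound 3 (0.52 log units; beyond the scatter). Compound 4 `COc1cccc(N2C(=O)CS/C2=N\c2csc(-c3ccc(Cl)cc3)c2)c1` is not yet measured and differs from compound 3 by chloro in place of methoxy on an aromatic carbon. Among the compounds with values here, no measured step exchanges methoxy for chloro. Within the data shown here, the steps that bear on it are a 3.3-fold lower number from compound 1 to compound 3 (0.52 log units; beyond the scatter) and an at least 4.2-fold lower number from compound 2 to compound 3 (0.63 log units; beyond the scatter), both with methoxy on the lower side, whereas an at least 1.3-fold higher number from compound 1 to compound 2 (0.11 log units; that floor lies within the scatter) stayed within the scatter. Compound 4 is therefore expected to give back part of that gain, a 2.1-fold higher number from compound 3 to compound 4 (0.33 log units; beyond the scatter), with an estimated 25000 nM between 9000 nM and 60000 nM.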

Compound 4, half-maximal inhibitory concentration: 24600 nM
For compound 4 the middle estimate is 1.0-fold (0.01 log units) above the measured one; low and high end bracket the measured number.
By their numbers in this assay, from the lowest: compound 3; then compounds 4 and 1 (each within the scatter of the next). At a limit, above all of these: compound 2.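

In this assay, going from 4-methoxyphenyl to 4-chlorophenyl gives a 2.1-fold higher number from compound 3 to compound 4 (0.32 log units; beyond the scatter), so chloro does not keep what methoxy gained at this position. Chloro in place of hydrogen stays within the scatter, a 1.6-fold lower number from compound 1 to compound 4 (0.19 log units; within the scatter), so among these compounds the clear gain over hydrogen rests on methoxy alone. The step from methyl is only a floor, an at least 2.0-fold lower number from compound 2 to compound 4 (0.30 log units; that floor lies within the scatter), and it rests on a limit: the limit of > 50000 nM in this assay, at which 1 of the 4 values shown sits.

On these data alone, whether an ethoxy, a hydroxy or an amine at this position would match methoxy stays open. As far as these compounds go, it is also open whether the methoxy gain would persist with a different group in place of the other methoxy on the shared core.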